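The compounds below may be only part of what the source reports. "The series", "measured", "known", "first", "only" and "open" are said of these compounds alone.

Working notes on the series. Two compounds are in hand. Compound 1 `CC(=O)Oc1ccc(/C=C/C(=O)OCCSc2nc(-c3ccc(S(C)(=O)=O)cc3)n(-c3ccccc3)n2)cc1OC(C)=O` gives 1210 nM in an assay on cells (strain Sprague-Dawley) for inhibition of Polyunsaturated fatty acid 5-lipoxygenase (Rattus norvegicus), with a stated time of 30 min; on this read-out lower numbers stand for stronger inhibition and higher numbers for weaker inhibition. Compound 2 `COc1cc(/C=C/C(=O)OCCSc2nc(-c3ccc(S(C)(=O)=O)cc3)n(-c3ccc(Br)cc3)n2)ccc1OC(C)=O` gives 940 nM in this assay, and the two numbers lie within the scatter of each other, so no order between them can be read. Compound 3 `COc1cc(/C=C/C(=O)OCCSc2nc(-c3ccc(S(C)(=O)=O)cc3)n(-c3ccc(C)cc3)n2)ccc1OC(C)=O` follows from compound 2 by methyl in place of bromo on an aromatic carbon. Going by the values given here, no measured pair shows this change, and no shift beyond the scatter is expected, so the expected step is a 1.1-fold higher number from compound 2 to compound 3 (0.03 log units; within the scatter). Compound 3 is estimated at 1000 nM, with a range from 400 nM to 2500 nM.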

Compound 3, half-maximal inhibitory concentration: 980 nM
For compound 3 the middle estimate is 1.0-fold (0.01 log units) above the measured one, and the stated range covers the measured number.
By their numbers in this assay, from the lowest: compounds 2, 3 and 1 (each within the scatter of the next).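

In this assay, going by these compounds alone, methyl in place of bromo on an aromatic carbon para to a large group gives a 1.0-fold higher number from compound 2 to compound 3 (0.02 log units; within the scatter), the first measured pair to differ at this position alone. At this position, 4-bromophenyl and 4-methylphenyl therefore cannot be told apart on this read-out. No evidence on hand bears on this result.

Still open, on these data alone, is whether an amine or a carboxylic acid at this position would shift the number beyond the scatter. The same question stands for a longer chain such as butyl.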